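A few compounds are considered here, and "the series" means these few. Any claim that something is new, unique, unknown or untested is made for them only; others in the source may bear on it.

Antiproliferative potency was followed in a functional assay on Jurkat cells (Homo sapiens) for antiproliferative activity, read by MTT assay; a lower number here means a stronger inhibitor, a higher number a weaker inhibitor. Compound 1 `COc1cccc(/C=C2\Cc3cc(OC)c(OC)cc3C2=O)c1` gives 12800 nM, and compound 2 `COc1cc2c(cc1OC)C(=O)/C(=C/c1cccc([N+](=O)[O-])c1)C2` gives 22000 nM. These two differ by methoxy in place of nitro on an aromatic carbon, and the resulting step, a 1.7-fold lower number from compound 2 to compound 1 (0.24 log units; within the scatter), is small.

Compound 3 `COc1cc2c(c([N+](=O)[O-])c1OC)C(=O)/C(=C/c1cc(C)c(O)c(C)c1)C2` is measured only as a limit, > 50000 nM, so no exact number is known for it; it is one of the cases described by the limit of > 50000 nM in this assay, at which 1 of the 3 values shown sits. How the core of compound 3 differs from the core of compound 2 is not broken down here.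

Compound 4 `COc1cc2c(c(OC)c1OC)C(=O)/C(=C/c1cc(C)c(O)c(C)c1)C2` remains to be tested. It differs from compound 3 by methoxy in place of nitro on an aromatic carbon. This is the same kind of change as that from compound 2 to compound 1, though it sits in different surroundings: here it is ortho to a fused ring and ortho to a methoxy group, meta to a fused ring and meta to a methoxy group, whereas before it was meta to a large group. Because the earlier step of a 1.7-fold lower number from compound 2 to compound 1 (0.24 log units; within the scatter) was small, the expected step of an at least 2.5-fold lower number from compound 3 to compound 4 (0.39 log units; beyond the scatter) is also modest, and compound 4 is estimated at 20000 nM, within 3000 nM to 60000 nM.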

Compound 4, half-maximal inhibitory concentration: 125 nM
The estimate for compound 4 lay 160-fold (2.20 log units) above the measured number, outside the stated range (below it).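

In this assay the swap of nitro for methoxy gives an at least 400-fold lower number from compound 3 to compound 4 (2.60 log units; beyond the scatter), a large step. On the other core the same swap gave a far smaller step, so the size of this change cannot simply be carried from one core to another in this series: the same change on two cores in this assay, a 1.7-fold lower number (0.24 log units; within the scatter) from compound 2 to compound 1 and an at least 400-fold lower number (2.60 log units; beyond the scatter) from compound 3 to compound 4, at least 230-fold (2.36 log units) apart, beyond the scatter of two such steps

As far as these compounds go, compound 3 is recorded only as a limit, > 50000 nM, so the exact size of the new step is unknown, and these two pairs do not show which feature of the cores separates the two results.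

The compounds shown leave open what an amine, a chlorine or a longer chain such as ethoxy would give in place of the methoxy group on the core of compound 4. They also leave open whether the hydroxy and methyl groups carried by compound 4 but not by compound 1 are what makes the step so much larger on this core.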